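Methoxy for cyano at the cytotoxicity limit

The compounds below may be only part of what the source reports. "The series", "measured", "known", "first", "only" and "open" are said of these compounds alone.

In an ADME assay on BE(2)-C cells (Homo sapiens) for cytotoxicity, read by MTT assay, with a stated time of 20 h (on this read-out lower numbers stand for higher toxicity in this test and higher numbers for lower toxicity in this test), compound 1 `CN(Cc1ccccc1)C(=O)C1CCN(C(=O)c2cc3ccccc3n2Cc2ccc([N+](=O)[O-])cc2)CC1` gives > 100000 nM, which is a limit. Compound 2 `CN(Cc1ccccc1)C(=O)C1CCN(C(=O)c2cc3ccccc3n2Cc2ccc(C#N)cc2)CC1` gives > 100000 nM, also a limit, so it has no numerical position. Both compounds sit at the limit of > 100000 nM in this assay, at which 2 of the 2 values shown sit. Among the measured compounds shown here, the only measured step is a step that the two limits leave unreadable from compound 1 to compound 2, so it offers no size to carry forward. Compound 3 `COc1ccc(Cn2c(C(=O)N3CCC(C(=O)N(C)Cc4ccccc4)CC3)cc3ccccc32)cc1` has methoxy in place of cyano on an aromatic carbon, para to a large group: methoxy in place of cyano on an aromatic carbon. No step beyond the scatter and no direction is expected in this assay. The expected step is a number no higher from compound 2 to compound 3 (the limit leaves the size open). For compound 3 the estimated value is 100000 nM, with an expected range of 30000 nM to 200000 nM.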

Compound 3, half-maximal cytotoxic concentration: 99200 nM
Compound 3: middle estimate off by 1.0-fold (0.00 log units), on the high side, and the stated range covers the measured number.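

In this assay, among the compounds shown here, compound 3, carrying 4-methoxybenzyl, gives 99200 nM as the only reading so far that is a number, so this position now has one measured value. Compound 2 gives > 100000 nM as a limit. Methoxy in place of cyano reads as a number no higher from compound 2 to compound 3 (the limit leaves the size open), so no size follows for methoxy against cyano or nitro: the limit of > 100000 nM in this assay, at which 2 of the 3 values shown sit.

With methoxy in place of nitro reading as a number no higher from compound 1 to compound 3 (the limit leaves the size open), open is whether an amine or a carboxylic acid on this aromatic carbon would give a number clearly lower than that of compound 3. Also open, from the compounds shown here alone, is whether a longer chain in place of methoxy would leave the reading unchanged.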